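Core aryl swap in a fused amide series: compound 4

The source may hold more compounds than are shown below. What is called first, only, known or untested is meant among the compounds shown, and "the series" means these compounds.

Measured so far in an ADME assay on HEK293 cells (Homo sapiens) for antiproliferative activity, read by MTT assay; a higher number here means a weaker inhibitor, a lower number a stronger inhibitor:
compound 1, `Nc1c(C(=O)N/N=C/c2ccc(Br)cc2)oc2nc(-c3cccs3)cc(C(F)(F)F)c12`, gives 86000 nM
compound 2, `Nc1c(C(=O)NC2CCCC2)oc2nc(-c3ccccc3)cc(C(F)(F)F)c12`, gives 85000 nM
compound 3, `Cc1ccc(/C=N/NC(=O)c2oc3nc(-c4ccccc4)cc(C(F)(F)F)c3c2N)cc1`, gives 69000 nM

Compound 1 stands at the top of the three numbers in this assay, but compound 2 and compound 3 both sit within the scatter of it, so the three are not separated. For the measured compounds named here, the only measured step, a 1.2-fold lower number from compound 2 to compound 3 (0.09 log units; within the scatter), exchanges one amide substituent for another and itself stays within the scatter.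

Compound 4, `Nc1c(C(=O)N/N=C/c2ccc(Br)cc2)oc2nc(-c3ccccc3)cc(C(F)(F)F)c12`, differs from compound 1 by phenyl in place of thiophen-2-yl on an aromatic carbon. Going by the values given here, no measured pair isolates this change. Compound 2 and compound 3 already carry the phenyl at this position and give numbers that are not distinguishable from compound 1, so no shift beyond the scatter is expected; the step of a 1.1-fold lower number from compound 1 to compound 4 (0.03 log units; within the scatter) is expected to be small in either direction. Compound 4 is estimated at 80000 nM, with a range from 40000 nM to 160000 nM.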

Compound 4, half-maximal inhibitory concentration: 64000 nM
Beside the measured number, compound 4's estimate is 1.3-fold (0.10 log units) above it; measured number inside the range.
By their numbers in this assay, from the lowest: compounds 4, 3, 2 and 1 (each within the scatter of the next).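

For the compounds shown here, the step of a 1.3-fold lower number from compound 1 to compound 4 (0.13 log units; within the scatter) in this assay is the only pair that isolates phenyl in place of thiophen-2-yl on this aromatic carbon, next to the ring nitrogen, and it shows that this swap does not separate the two compounds. With phenyl held constant, neither bromo in place of methyl, in the step of a 1.1-fold lower number from compound 3 to compound 4 (0.03 log units; within the scatter), nor the change of amide substituent, in the step of a 1.3-fold lower number from compound 2 to compound 4 (0.12 log units; within the scatter), separates compound 4 from its neighbours. No evidence is available that bears on these results.

On these data alone, whether any substituent at this position can move the number beyond the scatter remains open, for example an amine or a morpholine ring in place of phenyl. A carboxylic acid in place of bromo is equally untested ground for the aromatic ring on the amide side.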